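This account rests on a few compounds, and the source may have more. Where it says the series, first, only, none or still open, it means among the compounds named here.

The measured compounds:

compound 1 `COc1ccc(N2C[C@@H](C)N[C@@H](C)C2)cc1NS(=O)(=O)c1ccc(-c2ccccc2)cc1` gives 1 in a functional assay for agonist activity at growth hormone secretagogue receptor type 1 (Homo sapiens), read by FLIPR; a lower number here means a smaller maximal response, a higher number a larger maximal response
compound 2 `COc1ccc(N2C[C@@H](C)N[C@@H](C)C2)cc1NS(=O)(=O)c1ccc(-c2cncnc2)cc1` gives 0.6 in this assay
compound 3 `COc1ccc(N2C[C@@H](C)N[C@@H](C)C2)cc1NS(=O)(=O)c1ccc(N2CCCC2=O)cc1` gives 0.8 in this assay

All three share one core and differ only in the group at the far end of the sulfonamide ring. Compound 3 holds the middle place of the three: a number 0.20 lower from compound 1 to compound 3 (beyond the scatter), while a number 0.20 higher from compound 2 to compound 3 (beyond the scatter). The widest gap is seen in a number 0.40 lower from compound 1 to compound 2 (beyond the scatter).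

Compound 4 `COc1ccc(N2C[C@@H](C)N[C@@H](C)C2)cc1NS(=O)(=O)c1ccc(-n2cccn2)cc1` is the next variation on the same core: 1H-pyrazol-1-yl in place of 2-oxopyrrolidin-1-yl on an aromatic carbon. Among the steps already measured, the one from compound 1 to compound 2 swaps a carbon-only aromatic ring for an aromatic ring holding two nitrogens and brings a large fall, and the step from compound 2 to compound 3 moves from that aromatic ring to the lactam with a modest rise. For the measured compounds named here, the incoming pyrazolyl group is again a small aromatic ring with two hetero atoms, so compound 4 may settle nearer to compound 2 than compound 3 does, but no measured step shows this exact exchange. The expected change is a number 0.10 lower from compound 3 to compound 4 (within the scatter), most likely within the scatter. For compound 4 the estimate in this assay is 0.7, within 0.5 to 0.9.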

Compound 4, intrinsic activity: the largest response reached, as a fraction of the reference agonist's: 0.8
Compound 4: the middle estimate sits 0.10 below what was measured; the range from low to high includes it.
By their numbers in this assay, from the lowest: compound 2; then compounds 3 and 4 (each within the scatter of the next); then compound 1.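

At this position, on an aromatic carbon para to a large group, this assay does not separate the two five-membered rings: the exchange gives no change at the digits printed from compound 3 to compound 4 (within the scatter) even though one ring is non-aromatic and carries a double bond outside the ring, while the other is aromatic with 2 hetero atoms. An aromatic ring with two nitrogens therefore does not always go with the lowest response among these compounds, since the 1H-pyrazol-1-yl group gives a number 0.20 higher from compound 2 to compound 4 (beyond the scatter) when it replaces pyrimidin-5-yl, yet it still falls short of phenyl, with a number 0.20 lower from compound 1 to compound 4 (beyond the scatter). Nothing available here accounts for these differences in maximal response.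

On these data alone, it remains open whether the response at this position depends on having a ring at all, and a short alkyl chain, a primary amine or a carboxylic acid in place of these rings would test that. As far as these compounds go, it is also open whether the result is specific to 1H-pyrazol-1-yl or extends to other five-membered aromatic rings, such as imidazol-1-yl or thiazol-2-yl.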